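A Sulfone Amide Exchanged for an Oxanyl Carbamoyl Group

This account rests on a few compounds, and the source may have more. Where it says the series, first, only, none or still open, it means among the compounds named here.

For the measured compounds named here, compound 2 `CCN(CC)S(=O)(=O)c1ccc(S(=O)(=O)N2CCC[C@@H](C(=O)N3CCS(=O)(=O)CC3)C2)cc1` stands highest of the three numbers so far in a functional assay on MIA PaCa-2 cells (Homo sapiens) for inhibition, read by MTT assay, with a stated time of 7 days; on this read-out lower numbers stand for stronger inhibition and higher numbers for weaker inhibition: compound 2 gives 900 nM. Compound 1 `CCN(CC)S(=O)(=O)c1ccc(S(=O)(=O)N2CCC[C@@H](C(=O)N3CCC(F)(F)CC3)C2)cc1` gives 16 nM, and compound 3 `CCN(CC)S(=O)(=O)c1ccc(S(=O)(=O)N2CCC[C@@H](C(=O)N3CCOCC3)C2)cc1` gives 350 nM. Compound 4 `CCN(CC)S(=O)(=O)c1ccc(S(=O)(=O)N2CCC[C@@H](C(=O)NC3CCOCC3)C2)cc1` differs from compound 2 by (oxan-4-yl)amino in place of 1,1-dioxothiomorpholin-4-yl on a carbonyl carbon. The bearing steps are a 2.6-fold lower number from compound 2 to compound 3 (0.41 log units; beyond the scatter), a 56-fold higher number from compound 1 to compound 2 (1.75 log units; beyond the scatter) and a 22-fold higher number from compound 1 to compound 3 (1.34 log units; beyond the scatter), which show that the group on the carbonyl carbon moves the number widely, with the 1,1-dioxothiomorpholin-4-yl group giving the highest. Because compound 3 gives 350 nM, an oxygen-containing ring without the sulfone is expected to give a lower number, so a modest step is estimated as a 2.3-fold lower number from compound 2 to compound 4 (0.35 log units; beyond the scatter). Compound 4 is therefore estimated at 400 nM in this assay , within 80 nM to 2000 nM.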

Compound 4, half-maximal inhibitory concentration: 3770 nM
For compound 4 the middle estimate is 9.4-fold (0.97 log units) below the measured one, outside the stated range (above it).
By their numbers in this assay, from the lowest: compound 1; then compound 3; then compound 2; then compound 4.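

The widest new reading is an 11-fold higher number from compound 3 to compound 4 (1.03 log units; beyond the scatter), with (oxan-4-yl)amino in place of morpholin-4-yl on a carbonyl carbon, so an oxygen-containing ring alone does not keep the number low. Compound 4 is the weakest of the four, with a 4.2-fold higher number from compound 2 to compound 4 (0.62 log units; beyond the scatter) and a 240-fold higher number from compound 1 to compound 4 (2.37 log units; beyond the scatter), and its group is the only one of the four with a hydrogen-bond donor. No supporting evidence accounts for this result. The compounds shown leave open whether the amide hydrogen matters, which an N-methyl-(oxan-4-yl)amino group or a (4,4-difluorocyclohexyl)amino group could test.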